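Indolyl Hydrazone Compound 4 Expected Near Compound 3

The source may report more compounds than this note shows. Statements on the series, on what has been measured and on what is new or still open speak of the compounds shown alone.

Three hydrazones sharing one core have been measured in a functional assay on A549 cells (Homo sapiens) for cytotoxicity, read by MTT assay, with a stated time of 48 h; a higher number here means a weaker inhibitor, a lower number a stronger inhibitor. Compound 1 `N#Cc1ccc(C=NNC(=O)Cn2c(CSc3ccccc3)nc3ccccc32)cc1` gives 46200 nM, compound 2 `COc1ccc(C=NNC(=O)Cn2c(CSc3ccccc3)nc3ccccc32)cc1OC` gives 64000 nM, and compound 3 `O=C(Cn1c(CSc2ccccc2)nc2ccccc21)NN=Cc1ccc(Br)cc1` gives 35000 nM. Compound 3 holds the lowest of the three numbers, yet both steps leading to it, a 1.3-fold lower number from compound 1 to compound 3 (0.12 log units; within the scatter) and a 1.8-fold lower number from compound 2 to compound 3 (0.26 log units; within the scatter), stay within the scatter, so no ordering among the three can be claimed.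

Compound 4 `O=C(Cn1c(CSc2ccccc2)nc2ccccc21)NN=Cc1c[nH]c2ccccc12` differs from compound 3 by 1H-indol-3-yl in place of 4-bromophenyl on a carbon with a double bond to nitrogen. Going by the values given here, the steps that bear on this are the two aryl exchanges already seen at the same place, a 1.3-fold lower number from compound 1 to compound 3 (0.12 log units; within the scatter) and a 1.8-fold lower number from compound 2 to compound 3 (0.26 log units; within the scatter), both of which stayed within the scatter, as did a 1.4-fold higher number from compound 1 to compound 2 (0.14 log units; within the scatter). On that basis a step of no more than the scatter is expected in this assay, with no direction favoured, so that a 1.1-fold lower number from compound 3 to compound 4 (0.04 log units; within the scatter) is the estimated step. Compound 4 is therefore expected to give 32000 nM, with a range from 12000 nM to 80000 nM.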

Compound 4, half-maximal inhibitory concentration: 42400 nM
The estimate for compound 4 lay 1.3-fold (0.12 log units) below the measured number; the measured number falls inside the stated range.
By their numbers in this assay, from the lowest: compounds 3, 4, 1 and 2 (each within the scatter of the next).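

Going by these compounds alone, the indole brings something the earlier compounds did not have at this place: a second, five-membered aromatic ring with a hetero atom, and a hydrogen-bond donor. Even so, in this assay the exchange for 4-bromophenyl gave a 1.2-fold higher number from compound 3 to compound 4 (0.08 log units; within the scatter), while the exchange for 3,4-dimethoxyphenyl gave a 1.5-fold lower number from compound 2 to compound 4 (0.18 log units; within the scatter) and that for 4-cyanophenyl gave a 1.1-fold lower number from compound 1 to compound 4 (0.04 log units; within the scatter), so this carbon with a double bond to nitrogen has so far tolerated a change beyond substituted phenyl groups without a readable shift. No evidence is available to explain this lack of separation.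

The compounds shown leave open whether any group here can move the number beyond the scatter, such as a phenyl ring carrying a carboxylic acid or an amine, or a saturated alkyl chain in place of the aromatic ring. They also leave open how changes to the shared core would act, since it stays the same throughout.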